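Trimethoxyphenyl to dimethoxyphenyl in a cytotoxic sulfonamide series

The source may hold more compounds than are shown below. What is called first, only, known or untested is meant among the compounds shown, and "the series" means these compounds.

In a functional assay on SMMC-7721 cells (Homo sapiens) for cytotoxicity, read by MTT assay, with a stated time of 24 h (a higher number here means a weaker inhibitor, a lower number a stronger inhibitor), three compounds have been measured:
Compound 1, `COc1cc(/C=C2\CN(S(=O)(=O)c3ccc(F)cc3)C/C(=C\c3cc(OC)cc(OC)c3)C2=O)cc(OC)c1`, gives 8210 nM.
Compound 2, `COc1cc(/C=C2\CN(S(=O)(=O)c3ccc(F)cc3)C/C(=C\c3cc(OC)c(OC)c(OC)c3)C2=O)cc(OC)c1`, gives 5420 nM.
Compound 3, `COc1cc(/C=C2\CN(S(=O)(=O)c3ccc(NC(C)=O)cc3)C/C(=C\c3ccccc3F)C2=O)cc(OC)c1OC`, gives 3920 nM.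

Compound 3 has the lowest of the three numbers, but its gap to compound 2 lies within the scatter, so the two are not told apart; only compound 1 stands beyond the scatter from compound 3. How the core of compound 3 differs from the core of compound 2 is not broken down here.

Compound 4, `COc1cc(/C=C2\CN(S(=O)(=O)c3ccc(NC(C)=O)cc3)C/C(=C\c3ccccc3F)C2=O)cc(OC)c1`, is not yet measured in this assay. It is made from compound 3 by the change (hydrogen in place of methoxy on an aromatic carbon). The same change was already made from compound 2 to compound 1: hydrogen in place of methoxy on an aromatic carbon, and there it gave a 1.5-fold higher number from compound 2 to compound 1 (0.18 log units; within the scatter). Because that earlier step a 1.5-fold higher number from compound 2 to compound 1 (0.18 log units; within the scatter) stayed within the scatter, the step from compound 3 to compound 4 is expected to be of similar size, a 1.4-fold higher number from compound 3 to compound 4 (0.15 log units; within the scatter). Compound 4 is therefore estimated at 5500 nM, with a likely range from 2800 nM to 11000 nM.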

Compound 4, half-maximal inhibitory concentration: 5210 nM
Compound 4: middle estimate off by 1.1-fold (0.02 log units), on the high side, within the range that was stated.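

In this assay, putting hydrogen in place of methoxy, which turns 3,4,5-trimethoxyphenyl into 3,5-dimethoxyphenyl, gave a 1.3-fold higher number from compound 3 to compound 4 (0.12 log units; within the scatter). Set beside the earlier step, the change reads the same on both cores, with no difference that can be told between them: the same change on two cores in this assay, a 1.5-fold higher number (0.18 log units; within the scatter) from compound 2 to compound 1 and a 1.3-fold higher number (0.12 log units; within the scatter) from compound 3 to compound 4, 1.1-fold (0.06 log units) apart, within the scatter of two such steps. Going by these compounds alone, this shows only that the step stayed within the scatter on these two cores; it does not show that the methoxy group has a real effect on the number in either core, and two cores give no rule for others.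

The compounds shown compare only methoxy and hydrogen at this place, so it remains open how a hydroxyl group, an amine or a longer chain such as ethoxy would read there. Also open, going by these compounds, is whether the step would stay this small on a core carrying a carboxylic acid on the sulfonyl-bound ring.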